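The source may hold more compounds than are shown below. What is called first, only, known or untested is meant among the compounds shown, and "the series" means these compounds.

Results in a functional assay on HCT-116 cells (Homo sapiens) for antiproliferative activity, read by MTT assay, with a stated time of 48 h; on this read-out higher numbers stand for weaker inhibition and lower numbers for stronger inhibition:

- Compound 1 `CCCCCCC[C@@H](CCO)n1cnc2c(Cl)ncnc21` gives 10700 nM
- Compound 2 `CCCCCCC[C@H](CCO)n1cnc2c(Cl)ncnc21` gives 2670 nM
- Compound 3 `CCCCCCCC[C@@H](CCO)n1cnc2c(Cl)ncnc21` gives 3400 nM

Compound 3 at 3400 nM cannot be told apart from compound 2 at 2670 nM, and both inhibit more strongly than compound 1. The measured gap on that side is a 3.1-fold lower number from compound 1 to compound 3 (0.50 log units; beyond the scatter).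

The next compound, compound 4 `CCCCCCCC[C@H](CCO)n1cnc2c(Cl)ncnc21`, differs from compound 3 only in handedness at one carbon: the two compounds have the same atoms and bonds and differ only in configuration as drawn: 1 of 1 stereo elements differ; a stereocentre at a saturated chain carbon is drawn S in compound 3 and R in compound 4. Nothing leaves and nothing enters.

One measured step is of the same kind: a 4.0-fold lower number from compound 1 to compound 2 (0.60 log units; beyond the scatter). That gap comes down to the fact that compounds 1 and 2 differ only in the configuration as drawn, and it shows that the drawn configuration can matter in this series. It also involves the same change from S to R. One pair is thin evidence, so a step in the same direction and of similar size is expected in this assay, though with wide uncertainty. The expected step is a 3.4-fold lower number from compound 3 to compound 4 (0.53 log units; beyond the scatter). Compound 4 is estimated at 1000 nM, with an expected range of 350 nM to 3000 nM.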

Compound 4, half-maximal inhibitory concentration: 1120 nM
Beside the measured number, compound 4's estimate is 1.1-fold (0.05 log units) below it, and the stated range covers the measured number.
By their numbers in this assay, from the lowest: compound 4; then compounds 2 and 3 (each within the scatter of the next); then compound 1.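

With a 3.0-fold lower number from compound 3 to compound 4 (0.48 log units; beyond the scatter), the change from S to R at this carbon has now lowered the number in both pairs shown, so the effect of handedness no longer rests on a single pair. Methyl in place of hydrogen on the saturated chain carbon also lowers the number among the compounds drawn R, with a 2.4-fold lower number from compound 2 to compound 4 (0.38 log units; beyond the scatter). This change therefore gives a comparable step with either handedness at the stereocentre: the same change on two cores in this assay, a 3.1-fold lower number (0.50 log units; beyond the scatter) from compound 1 to compound 3 and a 2.4-fold lower number (0.38 log units; beyond the scatter) from compound 2 to compound 4, 1.3-fold (0.12 log units) apart, within the scatter of two such steps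

The compounds shown leave open whether a still longer chain would lower the number further or whether the trend would stop or reverse. They also leave open how an amine or a carboxylic acid in place of the hydroxyl, or a group other than chlorine on the shared core, would read.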